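The compounds below may be only part of what the source reports. "The series", "measured", "known", "first", "only" and "open" are said of these compounds alone.

Compound 1 `CC(C)(O/N=C(\C(=O)N[C@@H]1C(=O)N(S(=O)(=O)O)[C@@H]1Cn1cnnc1)c1csc(N)n1)C(=O)O`: 113 h
Compound 2 `CC(C)(O/N=C(\C(=O)N[C@@H]1C(=O)N(S(=O)(=O)O)[C@@H]1CN1C[C@H](CNC(=N)N)OC1=O)c1csc(N)n1)C(=O)O`: > 37 h (a limit)

In a physicochemical assay for metabolic stability, read by HPLC and mass spectrometry, in phosphate buffer, at 37 degrees C, at pH 7.4 (a lower number here means that the compound disappears faster, a higher number that the compound lasts longer), compound 1 gives 113 h. For compound 2, > 37 h is a limit of this assay and not a number. So compound 2 stands only at the limit of > 37 h in this assay, at which 1 of the 2 values shown sits.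

Compound 3 `CC(C)(O/N=C(\C(=O)N[C@@H]1C(=O)N(S(=O)(=O)O)[C@@H]1Cn1ncnc1CN)c1csc(N)n1)C(=O)O` differs from compound 2 on a saturated chain carbon bound to a saturated ring carbon: a group of 7 heavy atoms (3 carbon, 4 nitrogen; one five-membered aromatic ring with 3 hetero atoms) in place of a group of 11 heavy atoms (5 carbon, 4 nitrogen, 2 oxygen; one five-membered non-aromatic ring with 2 hetero atoms), on a saturated chain carbon bound to a saturated ring carbon. Within the data shown here, one measured step bears on this change, namely a step that the limit leaves unreadable from compound 1 to compound 2, and it gives no size to carry over. The nearest guide is compound 1 at 113 h, which also has a five-membered aromatic ring with 3 hetero atoms at this place, so a value near it is expected. Read against the limit, the expected change is a step that the limit leaves unreadable from compound 2 to compound 3, and its true size stays open. For compound 3 the estimate is 90 h, with an expected range of 35 h to 200 h.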

Compound 3, half-life: > 37 h
Compound 3 gave a limit, no number (the forecaster's own chance of this, stated with the estimate: 30%); the middle value is on the limit's open side.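

In this assay compound 3 gives > 37 h, which is a limit and not a number. Among these compounds, no step linking compound 1, compound 2 and compound 3 can be read. On these data alone, how long compound 2 and compound 3 truly last, and how either compares with compound 1, stays open.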